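The source may report more compounds than this note shows. Statements on the series, on what has been measured and on what is new or still open speak of the compounds shown alone.

Measured so far:
compound 1 `C=CCC(=N)NCCC[C@H](N)C(=O)O` — 13000 nM
compound 2 `C/C=C/CC(=N)NCCC[C@H](N)C(=O)O` — 79000 nM

In an assay on isolated protein for inhibition of N(G),N(G)-dimethylarginine dimethylaminohydrolase 1 (Homo sapiens) (a higher number here means a weaker inhibitor, a lower number a stronger inhibitor), compound 2 gives the higher of the two numbers; compound 1 gives 13000 nM, and the step of a 6.1-fold higher number from compound 1 to compound 2 (0.78 log units; beyond the scatter) lies beyond the scatter. Compound 3 `CCCC(=N)NCCC[C@H](N)C(=O)O` has not yet been measured. It differs from compound 2 by ethyl in place of prop-1-en-1-yl on a saturated chain carbon bound to a carbon with a double bond to nitrogen, so the double bond of the prop-1-en-1-yl group leaves and the chain becomes shorter by one carbon. Within the data shown here, the only measured step that bears on this, a 6.1-fold higher number from compound 1 to compound 2 (0.78 log units; beyond the scatter), shows that adding a carbon and shifting the double bond raised the number modestly. Undoing part of that change in compound 3 is therefore expected to bring the number back down, roughly toward compound 1, though the loss of the double bond has no measured counterpart here. Compound 3 is thus expected to show a step of a 4.0-fold lower number from compound 2 to compound 3 (0.60 log units; beyond the scatter) in this assay, with an estimate of 20000 nM and a range from 6000 nM to 70000 nM.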

Compound 3, half-maximal inhibitory concentration: 70000 nM
Compound 3: the middle estimate sits 3.5-fold (0.54 log units) below what was measured; measured number inside the range.
By their numbers in this assay, from the lowest: compound 1; then compounds 3 and 2 (each within the scatter of the next).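

In this assay, on a saturated chain carbon bound to a carbon with a double bond to nitrogen, ethyl and prop-1-en-1-yl cannot be told apart, with a 1.1-fold lower number from compound 2 to compound 3 (0.05 log units; within the scatter). The earlier step had changed both the length of the group and the place of its double bond, whereas ethyl, which is no longer than vinyl, still stands apart from it, with a 5.4-fold higher number from compound 1 to compound 3 (0.73 log units; beyond the scatter). A longer group is therefore not needed to reach the higher numbers, and among these three compounds only the vinyl of compound 1 gives the lower number.

As far as these compounds go, whether ethynyl or a cyclopropyl group at this place would read like vinyl or like ethyl remains open. Nothing available explains why vinyl differs from ethyl here.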